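The source may report more compounds than this note shows. Statements on the series, on what has been measured and on what is new or still open speak of the compounds shown alone.

Measured compounds:
- Compound 1 `O=S(=O)(c1ccccc1)c1nc2ccccc2nc1N1CCCC1`: 34800 nM
- Compound 2 `COc1ccc(S(=O)(=O)c2nc3ccccc3nc2N2CCc3ccccc3C2)cc1`: > 50000 nM
- Compound 3 `O=S(=O)(c1ccccc1)c1nc2ccccc2nc1N1CCCC(O)C1`: 310 nM

These values come from a functional assay on A549 cells (Homo sapiens) for cytotoxicity, read by MTT assay, with a stated time of 72 h; a higher number here means a weaker inhibitor, a lower number a stronger inhibitor. Compound 3, at 310 nM, has the lowest number of the series, making it the strongest inhibitor measured so far. The entry for compound 2, > 50000 nM, is a limit of the assay and not a number.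

Compound 4 `O=S(=O)(c1ccc(F)cc1)c1nc2ccccc2nc1N1CCCC(O)C1` differs from compound 3 in a single place: fluoro in place of hydrogen on an aromatic carbon. The phenyl of compound 3 thus becomes 4-fluorophenyl in compound 4. Among the measured compounds shown here, the only measured step, a 110-fold lower number from compound 1 to compound 3 (2.05 log units; beyond the scatter), was large, but it exchanged pyrrolidin-1-yl for 3-hydroxypiperidin-1-yl and left the phenyl untouched. For the measured compounds named here, it therefore says little about this new change, and no measured step isolates a change on that ring. With nothing pointing either way, no shift beyond the scatter is expected in this assay. The expected change is a 1.3-fold higher number from compound 3 to compound 4 (0.11 log units; within the scatter). For compound 4 the estimated value is 400 nM, with an expected range of 100 nM to 2000 nM.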

Compound 4, half-maximal inhibitory concentration: 8170 nM
Beside the measured number, compound 4's estimate is 20-fold (1.31 log units) below it, and the stated range ends below it.
By their numbers in this assay, from the lowest: compound 3; then compound 4; then compound 1. At a limit, above all of these: compound 2.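

In this assay, among the compounds shown here, adding fluoro to the phenyl ring gives a 26-fold higher number from compound 3 to compound 4 (1.42 log units; beyond the scatter), so this ring, which no earlier step had isolated, strongly affects the result. A change of one heavy atom, para to a large group, is enough for a large step toward a weaker inhibitor, just as exchanging pyrrolidin-1-yl for 3-hydroxypiperidin-1-yl was a large step toward a stronger one. Nothing measured here bears on why this small change has so large an effect.

Going by these compounds, it remains open whether the loss is specific to fluoro or would follow from other groups at this place, such as chloro, methyl or an amine. This single pair also cannot show whether fluoro would have the same effect with pyrrolidin-1-yl in place of 3-hydroxypiperidin-1-yl.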